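This account rests on a few compounds, and the source may have more. Where it says the series, first, only, none or still open, it means among the compounds named here.

Compound 2, `O=C(O)c1cccc(C2=C(c3cc(Br)ccc3OCc3ccc(F)cc3F)CCC2)c1`, stands in an assay on isolated protein for inhibition of prostaglandin E2 receptor EP3 subtype (Homo sapiens) (a higher number here means a weaker inhibitor, a lower number a stronger inhibitor), only at a limit: compound 2 gives < 3170 nM, which is a limit of the assay and not a number. Compound 1, `O=C(O)c1cccc(C2=C(c3cc(Br)ccc3OCc3ccc(Cl)cc3)CCC2)c1`, likewise gives a limit, < 3170 nM. Between them lies a step that the two limits leave unreadable from compound 1 to compound 2, the pair resting on (the limit of < 3170 nM in this assay, at which 2 of the 2 values shown sit). Compound 3, `CSc1ccc(OCc2ccc(F)cc2F)c(C2=C(c3cccc(C(=O)O)c3)CCC2)c1`, differs from compound 2 by methylsulfanyl in place of bromo on an aromatic carbon. Going by the values given here, no measured step touches this change, and the one measured step cannot be sized, so no direction can be read for this assay. Compound 3 is therefore expected near the limit, estimated at 1500 nM within 300 nM to 6000 nM, a step that the limit leaves unreadable from compound 2 to compound 3 expected to stay within the scatter.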

Compound 3, half-maximal inhibitory concentration: < 3170 nM
Compound 3: no number, only a limit (the forecaster's own chance of this, stated with the estimate: 60%); the middle value is on the limit's open side.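

No new step can be read in this assay, since compound 2 and compound 3 both stand only at a limit: the limit of < 3170 nM in this assay, at which 3 of the 3 values shown sit. From the compounds shown here alone, how strongly compounds 1, 2 and 3 each inhibit, and whether methylsulfanyl in place of bromo shifts this, stays open.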